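Acetyl to dimethylamino on the pendant phenyl ring

The source may report more compounds than this note shows. Statements on the series, on what has been measured and on what is new or still open speak of the compounds shown alone.

Three compounds of this series have been run in a functional assay on SN12C cells (Homo sapiens) for cytotoxicity, read by sulforhodamine B assay, with a stated time of 48 h, tested at 0.001 uM; on this read-out lower numbers stand for a stronger effect and higher numbers for a weaker effect at the one concentration tested. Compound 1 `COc1cc(C)cc(-c2c(-c3ccnc(-c4ccc(C(C)=O)cc4)c3)cnn2CC#N)c1` gives 94% in this assay. Compound 2 `COc1cc(C)cc(-c2nn(CC#N)cc2-c2ccc(-c3cccc(C(C)=O)c3)nc2)c1` gives 92%, and compound 3 `COc1cc(C)cc(-c2nn(CC#N)cc2-c2ccnc(-c3ccc(N(C)C)cc3)c2)c1` gives 100%. On these numbers compound 1 lies between the other two, and both gaps fall within the usual scatter, so the three read as one level of effect at this concentration.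

Compound 4 `COc1cc(C)cc(-c2c(-c3ccnc(-c4ccc(N(C)C)cc4)c3)cnn2CC#N)c1` is not yet measured. It differs from compound 1 in one place: dimethylamino in place of acetyl on an aromatic carbon. For the measured compounds named here, no measured pair in this set shares that exact change, so the expectation rests on the spread of the three values, which is flat, and on compound 3, which also carries a dimethylamino group and gives 100%. In this assay the step from compound 1 to compound 4 is expected to be a number 3 percentage points higher from compound 1 to compound 4 (within the scatter), that is, none beyond the scatter. Compound 4 is estimated at 97%, with a range from 86% to 106%.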

Compound 4, a percentage reported as activity, at one concentration (the size of the read-out at that concentration, not a potency): 97%
Estimate against measurement, compound 4: no gap at the digits printed; low and high end bracket the measured number.
By their numbers in this assay, from the lowest: compounds 2, 1, 4 and 3 (each within the scatter of the next).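

For the compounds shown here, exchanging 4-acetylphenyl for 4-(dimethylamino)phenyl gives the first direct reading at this position in this assay, with a step of a number 3 percentage points higher from compound 1 to compound 4 (within the scatter) on the core of compound 1. At this position, on an aromatic carbon para to a large group, acetyl and dimethylamino therefore read as one level of effect at the single concentration tested, so this read-out does not separate the two groups. No measurement among the data shown bears on why the two groups read alike.

As far as these compounds go, whether a carboxylic acid, a primary amine or a longer chain at this position would give a number beyond the scatter remains open. Also open, from the compounds shown here alone, is whether acetyl and dimethylamino would separate at a higher concentration, where the read-out may no longer stay at this one level.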